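This account rests on a few compounds, and the source may have more. Where it says the series, first, only, none or still open, it means among the compounds named here.

In an ADME assay on Vero cells (Chlorocebus sabaeus) for cytotoxicity, read by sulforhodamine B assay, with a stated time of 72 h (a higher number here means a weaker inhibitor, a lower number a stronger inhibitor), compound 1 `COc1ccc(COc2ccc3c(c2)[C@@H](O)CN(C)C3)cc1` reaches only a limit of the assay, > 50000 nM. Within the data shown here, compound 2 `CN1Cc2ccc(OCc3ccc(Br)cc3)cc2[C@@H](O)C1` gives 37000 nM, the only true number so far. Compound 3 `CN1Cc2ccc(OCc3ccc(-c4ccc(F)cc4)cc3)cc2[C@@H](O)C1` carries 4-fluorophenyl in place of bromo on an aromatic carbon. Among the measured compounds shown here, the one measured step at this site, with bromo in place of methoxy, is an at least 1.3-fold lower number from compound 1 to compound 2 (0.13 log units; that floor lies within the scatter), so it is a weak guide to a much larger swap. Only a modest move towards a lower number is expected, an estimated 1.9-fold lower number from compound 2 to compound 3 (0.27 log units; within the scatter). For compound 3 the expected value is 20000 nM, with an estimated range of 7000 nM to 50000 nM.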

Compound 3, half-maximal inhibitory concentration: 33800 nM
Compound 3: the middle estimate sits 1.7-fold (0.23 log units) below what was measured; low and high end bracket the measured number.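

In this assay, swapping bromo for the much larger 4-fluorophenyl, which brings a whole extra aromatic ring, gives a 1.1-fold lower number from compound 2 to compound 3 (0.04 log units; within the scatter) and so leaves the number where it was. Set against methoxy, the same group gives an at least 1.4-fold lower number from compound 1 to compound 3 (0.17 log units; that floor lies within the scatter) and no more can be read from that step. This figure is only a floor, set by a limit of the assay: the limit of > 50000 nM in this assay, at which 1 of the 3 values shown sits.

Still open, on these data alone, is whether an amine or a carboxylic acid on this aromatic carbon would move the number beyond the scatter. As far as these compounds go, a longer chain between the shared core and the outer ring remains equally open.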